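Swapping Allyl for 4-Fluorophenyl on an Amide-Type Nitrogen

The source may report more compounds than this note shows. Statements on the series, on what has been measured and on what is new or still open speak of the compounds shown alone.

In a functional assay on the whole organism for inhibition, with Lemna aequinoctialis as the target, tested at 1000 ug/mL (on this read-out lower numbers stand for less inhibition of growth and higher numbers for more inhibition of growth at the one concentration tested), compound 2 `C=CCNC(=S)N/N=C1\C(=O)Nc2ccc([N+](=O)[O-])cc21` gives 50%. That lies within the scatter of compound 1 `CCCCCCNC(=S)N/N=C1\C(=O)Nc2ccc([N+](=O)[O-])cc21` at 60%, while compound 3 `O=C1Nc2ccc([N+](=O)[O-])cc2/C1=N/NC(=S)Nc1ccccc1C(F)(F)F` gives 25%, a number lower than that of compound 2, with the gap beyond the scatter. Compound 4 `O=C1Nc2ccc([N+](=O)[O-])cc2/C1=N/NC(=S)Nc1ccc(F)cc1` carries 4-fluorophenyl in place of allyl on an amide-type nitrogen. For the measured compounds named here, the only measured step, a number 10 percentage points lower from compound 1 to compound 2 (within the scatter), stays within the scatter and exchanges one open chain for another, so it says little about a ring. Compound 3, with 25%, is the closer guide: it also has a six-membered aromatic ring of carbon only on that nitrogen. A downward step is therefore expected, a number 20 percentage points lower from compound 2 to compound 4 (beyond the scatter). In this assay, compound 4 is estimated at 30%, with an expected range of 15% to 50%.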

Compound 4, percent growth inhibition at one concentration: 20%
Estimate against measurement, compound 4: 10 percentage points above; the measured number falls inside the stated range.
By their numbers in this assay, from the lowest: compounds 4 and 3 (each within the scatter of the next); then compounds 2 and 1 (each within the scatter of the next).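

In this assay, putting 4-fluorophenyl in place of allyl on the amide-type nitrogen gives a number 30 percentage points lower from compound 2 to compound 4 (beyond the scatter), and putting it in place of hexyl gives a number 40 percentage points lower from compound 1 to compound 4 (beyond the scatter), so an aromatic ring here separates clearly from both open chains. Compound 3, with another aromatic ring at this nitrogen, gives 25%, within the scatter of compound 4, so both ring compounds sit low. No measurement shown explains this difference. From the compounds shown here alone, whether a saturated ring such as cyclohexyl would read like the chains or like the aromatic rings remains open, as does the effect of an amine at the end of a chain.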